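Replacing the Dichlorophenyl Group on the Sulfonyl of Compound 1

The source may hold more compounds than are shown below. What is called first, only, known or untested is meant among the compounds shown, and "the series" means these compounds.

Measured compounds:
compound 1, `Cn1c(=O)c(S(=O)(=O)c2ccc(Cl)cc2Cl)cc2cnc(Nc3ccc4[nH]ccc4c3)nc21`: 1000 nM
compound 2, `Cn1c(=O)c(S(=O)(=O)c2ccccc2)cc2cnc(Nc3cnc4[nH]ccc4c3)nc21`: 1000 nM
compound 3, `Cn1c(=O)c(S(=O)(=O)c2ccc(F)cc2F)cc2cnc(Nc3ccc4[nH]ncc4c3)nc21`: 30000 nM

All three numbers come from a functional assay on DU-145 cells (Homo sapiens) for inhibition, read by trypan blue exclusion, with a stated time of 72 h; a lower number here means a stronger inhibitor, a higher number a weaker inhibitor. In this assay compound 1 gives 1000 nM, and compound 2 gives 1000 nM, a number that does not differ from it at the digits shown; these two stand together as the lowest of the three. Compound 3 gives 30000 nM, the highest number of the set and well beyond the scatter from compound 1. Compound 3 differs from compound 1 in more than one part of the structure, so its higher number cannot be tied to any single change; the numbers only show that compound 3 is the weaker inhibitor of that pair.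

The compound still to be measured is compound 4, `Cn1c(=O)c(S(=O)(=O)c2ccc(O)cc2)cc2cnc(Nc3ccc4[nH]ccc4c3)nc21`. It differs from compound 1 in one place: 4-hydroxyphenyl in place of 2,4-dichlorophenyl on a sulfonyl sulfur. Among the measured compounds shown here, no measured pair isolates this change, since compound 2 differs from compound 1 both on the sulfonyl sulfur and elsewhere. A modest step is expected, in either direction, probably not far beyond the scatter. The estimate for compound 4 is 1500 nM, with a range from 400 nM to 6000 nM. That estimate means an expected step of a 1.5-fold higher number from compound 1 to compound 4 (0.18 log units; within the scatter).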

Compound 4, half-maximal inhibitory concentration: 250 nM
Estimate against measurement, compound 4: 6.0-fold (0.78 log units) above; measured number below the stated range.
By their numbers in this assay, from the lowest: compound 4; then compounds 1 and 2 (each within the scatter of the next); then compound 3.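

In this assay the group on the sulfonyl sulfur matters on its own: 4-hydroxyphenyl in place of 2,4-dichlorophenyl gives a 4.0-fold lower number from compound 1 to compound 4 (0.60 log units; beyond the scatter), a step beyond the scatter. Among the compounds shown here, this is the first pair in the set that differs in only one place, so this step can be tied to this swap, something the earlier compounds could not do. The swap removes both chlorines and adds a hydroxyl group, bringing one hydrogen-bond donor and one acceptor to a group that had neither, but no measurement shown here explains why the number falls.

The swap makes two changes at once, and compound 2, which carries a plain phenyl on the sulfonyl sulfur, also differs from compound 1 elsewhere, so it cannot show whether losing the chlorines or gaining the hydroxyl group accounts for the step. Also open, as far as these compounds go, is whether a methoxy group, an amine or a carboxylic acid in place of the hydroxyl group would give a similar number.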